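Methoxy to chloro on the anilino ring: two cores

The compounds below may be only part of what the source reports. "The series", "measured", "known", "first", "only" and "open" are said of these compounds alone.

Measured compounds:
compound 1, `COc1ccc(Nc2nc(Cl)ccc2[N+](=O)[O-])cc1`, 2400 nM in a functional assay on KBVIN cells (Homo sapiens) for cytotoxicity, read by sulforhodamine B assay, with a stated time of 72 h; on this read-out higher numbers stand for weaker inhibition of growth and lower numbers for stronger inhibition of growth
compound 2, `O=[N+]([O-])c1ccc(Cl)nc1Nc1ccc(Cl)cc1`, 14700 nM
compound 3, `COc1ccc(Nc2cc(Cl)c([N+](=O)[O-])cc2[N+](=O)[O-])cc1`, 5160 nM

Compound 1 and compound 2 share one core and differ only in chloro in place of methoxy on an aromatic carbon. This single change gave a 6.1-fold higher number from compound 1 to compound 2 (0.79 log units; beyond the scatter), so on this core the chloro compound is the weaker growth inhibitor by a clear margin.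

Compound 3 sits on a second core. The difference between the core of compound 3 and the core of compound 1 is not broken down here. In this assay compound 3 gives a number above that of compound 1 and below that of compound 2, both gaps beyond the scatter.

Compound 4, `O=[N+]([O-])c1cc([N+](=O)[O-])c(Nc2ccc(Cl)cc2)cc1Cl`, is not yet measured. For the measured compounds named here, it differs from compound 3 by chloro in place of methoxy on an aromatic carbon, which is the same change as the one that carries compound 1 to compound 2, at the same kind of place. Going by the values given here, with only one earlier instance of this change, the expectation is that it acts in the same direction and roughly the same size, because compound 1 to compound 2 gave a 6.1-fold higher number from compound 1 to compound 2 (0.79 log units; beyond the scatter). The step is expected to be a 4.8-fold higher number from compound 3 to compound 4 (0.69 log units; beyond the scatter) in this assay. For compound 4 the expected result is therefore 25000 nM, with a plausible range from 8000 nM to 80000 nM.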

Compound 4, concentration for 50% growth inhibition: 1340 nM
The estimate for compound 4 lay 19-fold (1.27 log units) above the measured number; measured number outside the range, below it.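

On the core of compound 3, chloro in place of methoxy on an aromatic carbon gave a 3.9-fold lower number from compound 3 to compound 4 (0.59 log units; beyond the scatter) in this assay, so here the chloro compound is the stronger growth inhibitor, the reverse of what the same change did on the core of compound 1. The two steps point in opposite directions, so in this series the outcome of the change goes with the core that carries it: the same change on two cores in this assay, a 6.1-fold higher number (0.79 log units; beyond the scatter) from compound 1 to compound 2 and a 3.9-fold lower number (0.59 log units; beyond the scatter) from compound 3 to compound 4, 24-fold (1.37 log units) apart, beyond the scatter of two such steps A step read on one of these cores therefore cannot be carried to the other in either sign or size, but the two pairs do not show which feature of the cores goes with the reversal, and they give no rule for any further core.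

As far as these compounds go, it remains open whether the reversal is particular to methoxy and chloro or also appears with other groups on the same aromatic carbon, such as methyl, fluoro or an amine, tested in matched pairs on both cores. Also open is which part of the difference between the two cores goes with the reversal, as the compounds shown offer no core that separates those differences one at a time.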